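A Smaller Halogen on the Benzyl Arm

This account rests on a few compounds, and the source may have more. Where it says the series, first, only, none or still open, it means among the compounds named here.

Compound 1, `O=c1ccc(-c2ccc3cn[nH]c3c2)cn1Cc1ccccc1C(F)(F)F`: 100 nM
Compound 2, `NC(=O)c1cccc(Cn2cc(-c3ccc4cn[nH]c4c3)ccc2=O)c1`: 106 nM
Compound 3, `NC(=O)c1ccc(Cn2cc(-c3ccc4cn[nH]c4c3)ccc2=O)cc1`: > 2000 nM (a limit of the assay)

Three compounds sharing one core were tested in an assay for inhibition of MAP kinase-interacting serine/threonine-protein kinase 2 (Homo sapiens), read by luminescence and ADP-Glo, with a stated time of 2 h; on this read-out higher numbers stand for weaker inhibition and lower numbers for stronger inhibition. Compound 1 gives 100 nM, and compound 2 gives 106 nM; the two numbers lie within the usual scatter of each other, so compound 1 stands at the low end of the two numbers shown without any order being drawn between them. For compound 3 the assay reports only a limit, > 2000 nM, and not a number (the limit of > 2000 nM in this assay, at which 1 of the 3 values shown sits). No pair among these measured compounds differs in only one place, so no measured step is available to set the size of the change that follows.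

Compound 4, `O=c1ccc(-c2ccc3cn[nH]c3c2)cn1Cc1ccccc1F`, differs from compound 1 by fluoro in place of trifluoromethyl on an aromatic carbon. The step from compound 1 to compound 4 in this assay is expected to be a modest weakening, a 2.0-fold higher number from compound 1 to compound 4 (0.30 log units; within the scatter), of a size near the edge of the scatter rather than well beyond it. Compound 4 is therefore expected to give about 200 nM, with a range from 60 nM to 800 nM.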

Compound 4, half-maximal inhibitory concentration: 37 nM
The estimate for compound 4 lay 5.4-fold (0.73 log units) above the measured number; the measured number lies below the stated range.
By their numbers in this assay, from the lowest: compound 4; then compounds 1 and 2 (each within the scatter of the next). At a limit, above all of these: compound 3.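

In this assay, among the compounds shown here, the change gives the first measured step at this position, on an aromatic carbon ortho to a large group: a 2.7-fold lower number from compound 1 to compound 4 (0.43 log units; beyond the scatter). For this pair, trifluoromethyl with its 4 heavy atoms is not required at this place, since fluoro with 1 heavy atom gives a lower number by a margin beyond the usual scatter, a result that compounds 1, 2 and 3 alone could not show because no two of them differ in only one place. Nothing measured here bears on why the number falls with this exchange.

As far as these compounds go, what a chloro group, a methoxy group or a plain hydrogen would give at this same carbon remains open, so one step cannot yet show whether the number follows the size of the group or something particular to fluoro. Also open, from the compounds shown here alone, is whether fluoro at this position would keep its lower number when combined with the carboxamide carried by compound 2, or with an amine or a carboxylic acid elsewhere on the benzyl arm.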